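From a cyclohexyl to a cyanophenyl on a shared core

The source may report more compounds than this note shows. Statements on the series, on what has been measured and on what is new or still open speak of the compounds shown alone.

Compound 1, `Fc1ccc(-c2noc(C3CCc4c(nnn4-c4ccc(F)nc4)C3)n2)cc1`, reaches only the limit of > 25100 nM in a functional assay on U2OS cells for positive allosteric modulation of metabotropic glutamate receptor 5 (Homo sapiens), read by calcium flux, in the presence of a further agent that is not named here (a higher number here means that more compound is needed for the effect, a lower number that less compound is needed), so no number is known for it. Compound 2, `CC(C)(C)n1nnc2c1CCC(c1nc(C3CCCCC3)no1)C2`, gives 200 nM in this assay. Among the values shown this is the only number. The other value, that of compound 1, is a limit: the limit of > 25100 nM in this assay, at which 1 of the 2 values shown sits. Compound 3, `CC(C)(C)n1nnc2c1CCC(c1nc(-c3ccc(C#N)cc3)no1)C2`, differs from compound 2 by 4-cyanophenyl in place of cyclohexyl on an aromatic carbon. Compound 3 is expected to stay close to compound 2, the step of a 1.3-fold lower number from compound 2 to compound 3 (0.12 log units; within the scatter) lying within the usual scatter or a little toward less compound needed. Compound 3 is therefore estimated at 150 nM, between 40 nM and 600 nM.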

Compound 3, half-maximal effective concentration: 79.4 nM
Compound 3: the middle estimate sits 1.9-fold (0.28 log units) above what was measured; the measured number falls inside the stated range.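

The place on the five-membered aromatic ring, between two ring nitrogen atoms, holds an aromatic group as well as a non-aromatic one: in this assay, 4-cyanophenyl in place of cyclohexyl gives a 2.5-fold lower number from compound 2 to compound 3 (0.40 log units; beyond the scatter). So less compound is needed with the larger group, a difference that goes beyond the usual scatter. Nothing measured here gives a reason for this step. Still open, from the compounds shown here alone, is whether the nitrile matters or the aromatic ring alone is enough, which a plain phenyl would test. Going by these compounds, how an amine or a carboxylic acid on that ring would fare also remains unknown.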